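Pentyl chain to tert-butyl-cyclohexenyl ring at the core

This account rests on a few compounds, and the source may have more. Where it says the series, first, only, none or still open, it means among the compounds named here.

Compound 1, `Cc1nc(C(F)(F)F)ccc1CNC(=O)C(C)c1ccc(NS(C)(=O)=O)c(F)c1`: 387 nM in an assay on CHO cells for antagonist activity at transient receptor potential cation channel subfamily V member 1 (Homo sapiens), read by FLIPR and calcium flux; on this read-out lower numbers stand for stronger inhibition and higher numbers for weaker inhibition
Compound 2, `CCCCCc1nc(C(F)(F)F)ccc1CNC(=O)C(C)c1ccc(NS(C)(=O)=O)c(F)c1`: 1 nM in this assay
Compound 3, `CC(C(=O)NCc1ccc(C(F)(F)F)nc1C1=C[C@H](C)CCC1)c1ccc(NS(C)(=O)=O)c(F)c1`: 0.1 nM in this assay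

Among these three numbers compound 2 stands second highest: the step of a 390-fold lower number from compound 1 to compound 2 (2.59 log units; beyond the scatter) separates it from compound 1, and the step of a 10-fold lower number from compound 2 to compound 3 (1.00 log units; beyond the scatter) separates it from compound 3. Compound 4, `CC(C(=O)NCc1ccc(C(F)(F)F)nc1C1=CCC(C(C)(C)C)CC1)c1ccc(NS(C)(=O)=O)c(F)c1`, has not yet been measured. Relative to compound 2 the change is 4-(tert-butyl)cyclohex-1-en-1-yl in place of pentyl on an aromatic carbon.

The step that bears most directly on this change is a 10-fold lower number from compound 2 to compound 3 (1.00 log units; beyond the scatter), where a 3-methylcyclohex-1-en-1-yl likewise replaces the pentyl on the same aromatic carbon and the number falls by a modest amount. The step of a 3900-fold lower number from compound 1 to compound 3 (3.59 log units; beyond the scatter) also shows that a cyclohexenyl ring at this position gives a very low number. Among the measured compounds shown here, in compound 4 the ring carries a 4-(tert-butyl) instead of a 3-methyl, a difference no measured pair covers, so the expectation rests on compound 3 alone. Because of a 10-fold lower number from compound 2 to compound 3 (1.00 log units; beyond the scatter), a modest fall is expected, a 5.0-fold lower number from compound 2 to compound 4 (0.70 log units; beyond the scatter), and compound 4 is estimated at 0.2 nM, within a range of 0.05 nM to 0.8 nM.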

Compound 4, inhibition constant: 0.2 nM
For compound 4 middle estimate and measured number coincide at the digits printed, and the stated range covers the measured number.
By their numbers in this assay, from the lowest: compounds 3 and 4 (each within the scatter of the next); then compound 2; then compound 1.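

With the 4-(tert-butyl)cyclohex-1-en-1-yl ring on this aromatic carbon, this assay shows a 5.0-fold lower number from compound 2 to compound 4 (0.70 log units; beyond the scatter), so a low number is not tied to the 3-methylcyclohex-1-en-1-yl ring alone. Measured against the methyl group, the same ring gives a 1900-fold lower number from compound 1 to compound 4 (3.29 log units; beyond the scatter). Exchanging one ring for the other gives a 2.0-fold higher number from compound 3 to compound 4 (0.30 log units; within the scatter), which lies within the scatter, so this assay cannot tell these two substituted rings apart, even though their substituents differ in both identity and ring position.

No measurement shown here accounts for these differences. As far as these compounds go, it remains open whether the double bond in the ring matters, and how a saturated cyclohexyl ring, a phenyl ring or a morpholine on this carbon would compare.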